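Fluoro removal on the chalcone arm of compound 1

The source may hold more compounds than are shown below. What is called first, only, known or untested is meant among the compounds shown, and "the series" means these compounds.

Measured compounds in a functional assay on PC-3 cells (Homo sapiens) for antiproliferative activity, read by MTT assay, with a stated time of 72 h; a lower number here means a stronger inhibitor, a higher number a weaker inhibitor:
compound 1 `O=C(COc1ccc(C(=O)/C=C/c2ccc(F)c(F)c2)cc1)N[C@H]1CCOC1=O`: 21900 nM
compound 2 `Cc1cc(Cl)ccc1NCC(=O)N[C@H]1CCOC1=O`: > 64000 nM, a limit of the assay
compound 3 `O=C(CNc1ccc(Br)cc1)N[C@H]1CCOC1=O`: > 64000 nM, a limit of the assay

Among the compounds with values here, compound 1 is the only compound of the three with a measured number; the other two sit at the limit of > 64000 nM in this assay, at which 2 of the 3 values shown sit. Within the data shown here, no step between measured compounds is available, so the size of the change from compound 1 cannot be read from the series itself.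

Compound 4 `O=C(COc1ccc(C(=O)/C=C/c2cccc(F)c2)cc1)N[C@H]1CCOC1=O` differs from compound 1 by hydrogen in place of fluoro on an aromatic carbon. Among the measured compounds shown here, with no comparable step on hand, the expected step from compound 1 to compound 4 is a 1.4-fold higher number from compound 1 to compound 4 (0.14 log units; within the scatter), likely no more than the usual scatter. Compound 4 is therefore estimated at 30000 nM, between 10000 nM and 90000 nM.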

Compound 4, half-maximal inhibitory concentration: 23200 nM
Beside the measured number, compound 4's estimate is 1.3-fold (0.11 log units) above it; measured number inside the range.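

In this assay, going from 3,4-difluorophenyl to 3-fluorophenyl gives a 1.1-fold higher number from compound 1 to compound 4 (0.03 log units; within the scatter), the first step readable in the series. The two compounds cannot be told apart here, so the fluoro para to a large group is not required for the modest activity of compound 1. Compound 2 and compound 3 each give a limit, not a number: the limit of > 64000 nM in this assay, at which 2 of the 4 values shown sit.

Open, from the compounds shown here alone, is whether the remaining fluoro on the chalcone arm is needed. Also open, going by these compounds, is how an amine, a methoxy group or a carboxylic acid at this position would read.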